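This account rests on a few compounds, and the source may have more. Where it says the series, first, only, none or still open, it means among the compounds named here.

Series notes, values in a functional assay on Caco-2 cells (Homo sapiens) for inhibition, read by sulforhodamine B assay, with a stated time of 72 h; a higher number here means a weaker inhibitor, a lower number a stronger inhibitor:

Compound 1 `CCCNC(=C\C(=O)/C=C/c1ccc(O)c(OC)c1)/C=C/c1ccc(O)c(OC)c1` gives 22000 nM
Compound 2 `C=CCNC(=C\C(=O)/C=C/c1ccc(O)c(OC)c1)/C=C/c1ccc(O)c(OC)c1` gives > 25000 nM

Compound 2 has no number on this scale, only a limit of the assay, > 25000 nM. The next structure is compound 3 `CCCCNC(=C\C(=O)/C=C/c1ccc(O)c(OC)c1)/C=C/c1ccc(O)c(OC)c1`, where butylamino replaces allylamino. This is propyl in place of vinyl on a saturated chain carbon bound to an amine nitrogen.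

Within the data shown here, one measured step bears on this change, since it falls at the same place: an at least 1.1-fold higher number from compound 1 to compound 2 (0.05 log units; that floor lies within the scatter). That step sets only a floor, so it gives no measured size for a change on this chain. With only an at least 1.1-fold higher number from compound 1 to compound 2 (0.05 log units; that floor lies within the scatter) to go on, no step beyond the scatter is expected in this assay, and no direction can be favoured. Among the measured compounds shown here, the only actual number nearby is that of compound 1 at 22000 nM, so the estimate stays in that region. A further limit result for compound 3 would be no surprise.

For compound 3 the expected value is 20000 nM, with an estimated range of 10000 nM to 35000 nM. This corresponds to an expected at least 1.2-fold lower number from compound 2 to compound 3 (0.09 log units; that floor lies within the scatter).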

Compound 3, half-maximal inhibitory concentration: 23800 nM
Compound 3: the middle estimate sits 1.2-fold (0.08 log units) below what was measured; the range from low to high includes it.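

In this assay, among these compounds, the step of a 1.1-fold higher number from compound 1 to compound 3 (0.03 log units; within the scatter) is the first measured size on this chain, since both of its ends carry actual numbers. Methyl in place of hydrogen on a saturated chain carbon, three bonds along the chain from an amine nitrogen, therefore stays within the scatter, and propylamino and butylamino cannot be told apart in this assay. The other new step, an at least 1.0-fold lower number from compound 2 to compound 3 (0.02 log units; that floor lies within the scatter), is only a floor and gives no measured size or direction for propyl in place of vinyl, as its starting end is a limit of the assay: the limit of > 25000 nM in this assay, at which 1 of the 3 values shown sits.

From the compounds shown here alone, with only propyl, allyl and butyl on the amine nitrogen, it remains open whether a longer chain such as octyl would shift the value beyond the scatter. Going by these compounds, it is equally open whether a polar end group on the chain, such as a terminal amine or a carboxylic acid, or a benzyl group in place of the chain, would move the value away from this region.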